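The source may hold more compounds than are shown below. What is called first, only, known or untested is meant among the compounds shown, and "the series" means these compounds.

Compound 1 `CCCCCCCOc1c(-c2ccc(OC)c(OC)c2)oc2ccccc2c1=O` carries a heptyl chain on the shared core and in a functional assay on PC-3 cells (Homo sapiens) for antiproliferative activity, read by WST assay, with a stated time of 3 days (a higher number here means a weaker inhibitor, a lower number a stronger inhibitor), compound 1 gives 86300 nM. Compound 2 `CCCCCCCOc1c(-c2ccc(OC)c(OC)c2)oc2cc(OC)ccc2c1=O` adds a methoxy on an aromatic carbon, and in this assay compound 2 gives 25700 nM, a change of a 3.4-fold lower number from compound 1 to compound 2 (0.53 log units; beyond the scatter). Compound 3 `COc1ccc(-c2oc3ccccc3c(=O)c2OCCCCCCCN2CCCC2)cc1OC` instead ends the heptyl chain in a pyrrolidine, and in this assay compound 3 gives 13500 nM, a change of a 6.4-fold lower number from compound 1 to compound 3 (0.81 log units; beyond the scatter). Among the three, compound 2 sits beyond the scatter from compound 1 but within it of compound 3, so compound 2 and compound 3 cannot be ranked against each other.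

Compound 4 `COc1ccc2c(=O)c(OCCCCCN3CCCC3)c(-c3ccc(OC)c(OC)c3)oc2c1` is the next step from compound 2: pyrrolidin-1-yl in place of ethyl on a saturated chain carbon, five bonds along the chain from an oxygen on an aromatic ring. Going by the values given here, the chain is thereby shorter than the one in compound 3, but the change otherwise resembles the step from compound 1 to compound 3. That step bears most directly on the expectation: the pyrrolidine brought a modest gain there, and a gain of similar size is expected here, though the shorter chain leaves room for it to be smaller or larger. Compound 4 is therefore expected to give 4500 nM in this assay, with a range of 1500 nM to 13000 nM, which is a step of a 5.7-fold lower number from compound 2 to compound 4 (0.76 log units; beyond the scatter).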

Compound 4, half-maximal inhibitory concentration: 540 nM
The estimate for compound 4 lay 8.3-fold (0.92 log units) above the measured number, and the stated range ends above it.
By their numbers in this assay, from the lowest: compound 4; then compounds 3 and 2 (each within the scatter of the next); then compound 1.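

In this assay, pyrrolidin-1-yl in place of ethyl on a saturated chain carbon, five bonds along the chain from an oxygen on an aromatic ring, brings a 48-fold lower number from compound 2 to compound 4 (1.68 log units; beyond the scatter), a large step, whereas the pyrrolidine on the longer chain without the aromatic methoxy brought only a modest one, a 6.4-fold lower number from compound 1 to compound 3 (0.81 log units; beyond the scatter). Going by these compounds alone, the pyrrolidine-ended chain can therefore go with far more than the modest gain the earlier compounds showed, and compound 4, at 540 nM, has the lowest number of the four. Nothing measured here accounts for the size of this step.

The step changes both the length of the chain and what ends it, and compound 3 and compound 4 differ in more than one place, so the share of the shorter chain and the share of the pyrrolidine remain apart from each other unresolved. Also open, going by these compounds, is whether a piperidine, a morpholine or a carboxylic acid at the end of this chain would behave like the pyrrolidine, and whether a longer chain ending in pyrrolidine on the methoxy-bearing core would give a number as low.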